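Adding an Isopropyl Group to Compound 1

This account rests on a few compounds, and the source may have more. Where it says the series, first, only, none or still open, it means among the compounds named here.

Compound 1 `Cc1ccccc1OCC(=O)Nc1ccc(OCC(=O)O)c(F)c1` stands second highest of three compounds in a functional assay on CHO cells for agonist activity at Free fatty acid receptor 1 (Homo sapiens), read by FLIPR, tested at 100 nM (on this read-out lower numbers stand for a weaker effect and higher numbers for a stronger effect at the one concentration tested), where compound 1 gives 20.8%. Compound 2 `Cc1cccc(OCC(=O)Nc2ccc(OCC(=O)O)c(F)c2)c1` gives 45.4% and compound 3 `COc1ccc(OCC(=O)Nc2ccc(OCC(=O)O)c(F)c2)cc1` gives 5.73%. Compound 4 `Cc1ccc(C(C)C)cc1OCC(=O)Nc1ccc(OCC(=O)O)c(F)c1` differs from compound 1 only by isopropyl in place of hydrogen on an aromatic carbon. For the measured compounds named here, no measured step adds a group to this ring while keeping the methyl in place; the measured steps instead swap one ring group for another: a number 24.6 percentage points higher from compound 1 to compound 2 (beyond the scatter), a number 15.1 percentage points lower from compound 1 to compound 3 (beyond the scatter) and a number 39.7 percentage points lower from compound 2 to compound 3 (beyond the scatter). These show that what sits on this ring can move the read-out beyond the scatter in either direction, so a shift is plausible but its direction has no direct support. Compound 4 is therefore expected near 30%, between 10% and 55%, which means an expected step of a number 9.2 percentage points higher from compound 1 to compound 4 (within the scatter) in this assay.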

Compound 4, a percentage reported as activity, at one concentration (the size of the read-out at that concentration, not a potency): 14.6%
The estimate for compound 4 lay 15.4 percentage points above the measured number, and the stated range covers the measured number.
By their numbers in this assay, from the lowest: compounds 3, 4 and 1 (each within the scatter of the next, the first and the last beyond it); then compound 2.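

For the compounds shown here, compound 4 is the only compound here that adds a group to the ring of compound 1 while keeping the methyl. In this assay, isopropyl in place of hydrogen gives a number 6.2 percentage points lower from compound 1 to compound 4 (within the scatter), so this position, para to a methyl group, takes a group of 3 carbon atoms without a shift beyond the usual scatter. Nothing available explains this result. Going by these compounds, whether an amine or a nitrile at this position would also leave the read-out within the scatter remains open. So does whether isopropyl would behave the same way on the ring of compound 2.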